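The compounds below may be only part of what the source reports. "The series", "measured", "known", "first", "only" and "open" are said of these compounds alone.

Compound 1 `CCNCc1ccc(Cl)c(-c2ccccc2OC)c1` carries an ethylamino group on a saturated carbon that hangs from the shared core. In an assay on isolated protein for binding affinity to 5-hydroxytryptamine receptor 1E (Homo sapiens) (a higher number here means a weaker inhibitor, a lower number a stronger inhibitor), compound 1 gives > 10000 nM, which is a limit of the assay rather than a measured number. Compound 2 `CCN(CC)Cc1ccc(Cl)c(-c2ccccc2OC)c1` adds an ethyl in place of hydrogen on the amine nitrogen. In this assay compound 2 gives > 10000 nM, again a limit and not a number. The step that the two limits leave unreadable from compound 1 to compound 2 therefore has no readable size, since both values sit at the limit of > 10000 nM in this assay, at which 2 of the 2 values shown sit, and nothing is known beyond that boundary.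

Compound 3 `CCCNCc1ccc(Cl)c(-c2ccccc2OC)c1` is the next compound to be tested. Its change from compound 1 is methyl in place of hydrogen on a saturated chain carbon, two bonds along the chain from an amine nitrogen. Among the measured compounds shown here, the only measured step that bears on it is the one from compound 1 to compound 2, and that step is unreadable, so the data give no direction for a chain extension of this kind. The expectation is that compound 3 stays near the same boundary, at 20000 nM with a range from 5000 nM to 80000 nM, which corresponds to an estimated step that the limit leaves unreadable from compound 1 to compound 3 of no readable size.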

Compound 3, inhibition constant: > 10000 nM
Compound 3 gave a limit, no number; the forecaster's own chance of this, stated with the estimate: 85%; the middle value does not contradict the limit.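

In this assay compound 3 gives > 10000 nM, which is a limit of the assay and not a number, so the steps from compound 1 and from compound 2 to compound 3 cannot be read: the limit of > 10000 nM in this assay, at which 3 of the 3 values shown sit.

The compounds shown leave open how strongly each one binds, and whether their different amine groups change the binding in this assay at all.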